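The source may hold more compounds than are shown below. What is called first, only, known or untested is meant among the compounds shown, and "the series" means these compounds.

In an ADME assay on Vero cells (Chlorocebus sabaeus) for cytotoxicity (a lower number here means that less compound is tolerated, a higher number that more compound is tolerated), compound 1 (`Oc1ccc(-c2nc3cc(C(F)(F)F)ccc3[nH]2)cc1`) gives > 100000 nM as a limit of the assay and not as a number. Two relatives with the shared core do return numbers: compound 2 (`COc1ccc(-c2nc3cc(C(F)(F)F)ccc3[nH]2)c(OC)c1OC`) reads 70000 nM in the same test, and compound 3 (`COc1ccc(-c2nc3cc(C(F)(F)F)ccc3[nH]2)c([N+](=O)[O-])c1`) reads 20000 nM there. Compound 4 (`Fc1ccc(-c2nc3cc(C(F)(F)F)ccc3[nH]2)cc1`) has fluoro in place of hydroxy on an aromatic carbon, para to a large group (fluoro in place of hydroxy on an aromatic carbon). Among the measured compounds shown here, no measured pair isolates this change, so the expectation is tentative. It leans on compound 2 at 70000 nM and compound 3 at 20000 nM, neither of which carries the hydroxy group. A moderate downward move in this assay is expected, an estimated at least 2.0-fold lower number from compound 1 to compound 4 (0.30 log units; that floor lies within the scatter) in all. For compound 4 the estimated value is 50000 nM within an expected range of 15000 nM to 100000 nM in this test.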

Compound 4, half-maximal cytotoxic concentration: 60000 nM
Compound 4: the middle estimate sits 1.2-fold (0.08 log units) below what was measured; the range from low to high includes it.
By their numbers in this assay, from the lowest: compound 3; then compounds 4 and 2 (each within the scatter of the next). At a limit, above all of these: compound 1.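

In this assay, fluoro in place of hydroxy on an aromatic carbon, para to a large group, is now isolated as a single change, and it gives an at least 1.6-fold lower number from compound 1 to compound 4 (0.22 log units; that floor lies within the scatter). Compound 1 gives > 100000 nM, which is a limit of the assay and not a number. The full size of this step stays open because one end of the pair rests on that limit: the limit of > 100000 nM in this assay, at which 1 of the 4 values shown sits.

The compounds shown leave open how an amine, a carboxylic acid or a longer chain at this position would read in this assay. They also leave open whether this step would appear on the other substituted relatives.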